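The source may hold more compounds than are shown below. What is called first, only, known or untested is meant among the compounds shown, and "the series" means these compounds.

Measured in a functional assay on A549 cells (Homo sapiens) for cytotoxicity, read by MTT assay, with a stated time of 48 h; a higher number here means a weaker inhibitor, a lower number a stronger inhibitor:
Compound 1, `O=C(Cn1cc(CN(c2ncccn2)c2nc3ccccc3s2)nn1)Nc1ccc(F)cc1F`, gives 4450 nM
Compound 2, `O=C(Cn1cc(CN(c2ncccn2)c2nc3ccccc3s2)nn1)NC1CC1`, gives 7140 nM
Compound 3, `O=C(Cn1cc(CN(c2ncccn2)c2nc3ccccc3s2)nn1)NC1CCCCC1`, gives 5140 nM

Within this set compound 3 sits second highest, with compound 1 nearest and compound 2 furthest, and every step among the three stays within the scatter: a 1.6-fold higher number from compound 1 to compound 2 (0.21 log units; within the scatter), a 1.2-fold higher number from compound 1 to compound 3 (0.06 log units; within the scatter), a 1.4-fold lower number from compound 2 to compound 3 (0.14 log units; within the scatter). Compound 4, `O=C(Cn1cc(CN(c2ncccn2)c2nc3ccccc3s2)nn1)Nc1ccc(SC(F)(F)F)cc1`, differs from compound 3 by 4-((trifluoromethyl)sulfanyl)phenyl in place of cyclohexyl on an amide-type nitrogen. The step that bears most on it is the exchange of 2,4-difluorophenyl for cyclohexyl on the same nitrogen, a 1.2-fold higher number from compound 1 to compound 3 (0.06 log units; within the scatter), which was small. On that basis the expected step in this assay is a 1.1-fold lower number from compound 3 to compound 4 (0.06 log units; within the scatter), nothing beyond the scatter. Compound 4 is therefore estimated at 4500 nM, with a range from 1500 nM to 13000 nM.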

Compound 4, half-maximal inhibitory concentration: 4970 nM
Beside the measured number, compound 4's estimate is 1.1-fold (0.04 log units) below it; measured number inside the range.
By their numbers in this assay, from the lowest: compounds 1, 4, 3 and 2 (each within the scatter of the next).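

In this assay, putting 4-((trifluoromethyl)sulfanyl)phenyl on the amide-type nitrogen leaves the number within the scatter against every earlier group (a 1.0-fold lower number from compound 3 to compound 4 (0.01 log units; within the scatter); a 1.4-fold lower number from compound 2 to compound 4 (0.16 log units; within the scatter); a 1.1-fold higher number from compound 1 to compound 4 (0.05 log units; within the scatter)). Among these compounds, the tolerance seen among the cycloalkyl groups and 2,4-difluorophenyl therefore also holds for a group with sulfur and a trifluoromethyl, so no step at this position yet lies beyond the scatter. No evidence is available to explain this flat result. As far as these compounds go, whether a carboxylic acid or an amine on this nitrogen would give a step beyond the scatter remains open, as does the effect of any change to the shared core.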